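The compounds below may be only part of what the source reports. "The series", "measured", "known", "first", "only" and "open" are said of these compounds alone.

Measured compounds:
Compound 1, `Cc1nc(NC(=O)Cn2nnc(-c3ccccc3)n2)n(-c2ccccc2)n1` — "not active" (no number reported)
Compound 2, `Cc1cc(NC(=O)Cn2nnc(-c3cccc(Cl)c3)n2)n(C2CCCCC2)n1` — 89%

Of the compounds shown here, two have been tested in an assay on HEK293 cells for activation of Kir3.1/Kir3.2 (Homo sapiens), read by thallium flux; on this read-out higher numbers stand for larger maximal responses and lower numbers for smaller maximal responses. Compound 1, with structure `Cc1nc(NC(=O)Cn2nnc(-c3ccccc3)n2)n(-c2ccccc2)n1`, was reported as "not active" (no number reported) in this assay, so no number stands for it. Compound 2, with structure `Cc1cc(NC(=O)Cn2nnc(-c3cccc(Cl)c3)n2)n(C2CCCCC2)n1`, reaches 89% in this assay. It therefore holds the only number shown, and there is nothing measured to set beside it, so no step between measured compounds can be described.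

Compound 3, with structure `Cc1cc(NC(=O)Cn2nnc(-c3ccc(Cl)c(C)c3)n2)n(C2CCCCC2)n1`, has not yet been measured in this assay. Compared with compound 2 it differs in one place: 4-chloro-3-methylphenyl in place of 3-chlorophenyl on an aromatic carbon. The group that leaves and the group that enters are both a single aromatic ring of carbon bearing a chlorine, and the entering group carries one more carbon as a methyl.

Among the measured compounds shown here, with no measured step of this kind to draw on, the expected step from compound 2 to compound 3 in this assay is estimated as a number 9 percentage points lower from compound 2 to compound 3 (within the scatter), a small change that may well fall within the usual scatter. The expected value for compound 3 in this assay is therefore 80%, with a range from 50% to 110%.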

Compound 3, largest response reached (Emax), in percent of the reference or control that the assay uses: 89%
The estimate for compound 3 lay 9 percentage points below the measured number; low and high end bracket the measured number.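

In this assay, among the compounds shown here, putting 4-chloro-3-methylphenyl in place of 3-chlorophenyl gives no change at the digits printed from compound 2 to compound 3 (within the scatter) and so provides the first comparison of compounds that differ in one place. At this position, on an aromatic carbon of the five-membered aromatic ring with 4 nitrogen, a phenyl ring with one more carbon and its chlorine at a different ring position therefore still gives a maximal response level with that of the 3-chlorophenyl compound. No measurement shown explains why the two compounds read alike.

The methyl and the changed chlorine position arrive together, so the effect of each alone cannot be read, and they might cancel or each do little; compound 1 differs from the other two in more than one place, so its lack of activity cannot be tied to any one group. Also open, going by these compounds, is how this position would respond to a phenyl ring carrying an amine or a carboxylic acid, or to an unsubstituted phenyl ring on the same core as compound 2.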